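This account rests on a few compounds, and the source may have more. Where it says the series, first, only, none or still open, it means among the compounds named here.

Measured compounds in a functional assay on HT-29 cells (Homo sapiens) for inhibition, read by sulforhodamine B assay, with a stated time of 48 h, tested at 0.01 uM; on this read-out lower numbers stand for a stronger effect and higher numbers for a weaker effect at the one concentration tested:
compound 1 `O=C(Nc1cccc(-n2cc(-c3ccncc3)c(-c3cc(O)cc(Cl)c3)n2)c1)Nc1ccc(Cl)c(Cl)c1` gives 91%
compound 2 `COc1cc(Cl)cc(-c2nn(-c3cccc(NC(=O)Nc4ccc(Cl)c(Cl)c4)c3)cc2-c2ccncc2)c1` gives 103%

Going by the values given here, compound 2 stands highest of the two numbers in this assay; the nearest, compound 1, lies lower by a number 12 percentage points higher from compound 1 to compound 2 (beyond the scatter), the only measured step, and it concerns methyl in place of hydrogen on an oxygen on an aromatic ring. Compound 3 `COc1cc(Cl)cc(-c2nn(-c3cccc(NC(=O)c4cccc(C(F)(F)F)c4)c3)cc2-c2ccncc2)c1` is not yet measured. It differs from compound 2 as 3-(trifluoromethyl)phenyl in place of (3,4-dichlorophenyl)amino on a carbonyl carbon. Among the compounds with values here, no measured step touches the carbonyl carbon or its amide-type nitrogen, so the one known step gives no guide to the size or direction of this change. With both measured numbers close to the top of the scale in this assay, the expectation for compound 3 is a number in the same region, a step of a number 5 percentage points lower from compound 2 to compound 3 (within the scatter) that is not expected to exceed the scatter. The estimate for compound 3 is 98%, with a range from 82% to 110%.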

Compound 3, a percentage reported as activity, at one concentration (the size of the read-out at that concentration, not a potency): 90%
Estimate against measurement, compound 3: 8 percentage points above, and the stated range covers the measured number.
By their numbers in this assay, from the lowest: compounds 3 and 1 (each within the scatter of the next); then compound 2.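

In this assay, the carbonyl carbon is a second place in the series where a change moves the read-out beyond the scatter: a number 13 percentage points lower from compound 2 to compound 3 (beyond the scatter), towards a stronger effect at the one concentration tested. Exchanging (3,4-dichlorophenyl)amino for 3-(trifluoromethyl)phenyl thus keeps the read-out in the same upper region while shifting it, but the exchange removes the amino nitrogen and replaces the ring substituents in a single step, so the shift cannot be assigned to either part. Nothing shown explains the step.

Open, going by these compounds, is which part carries the shift; (3-(trifluoromethyl)phenyl)amino or 3,4-dichlorophenyl on the carbonyl carbon would separate the two. Also open, on these data alone, is whether the step holds with the hydroxy group of compound 1 in place of the methoxy group.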